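Ethylcarbamoyl in place of the carbamate on the ring

A few compounds are considered here, and "the series" means these few. Any claim that something is new, unique, unknown or untested is made for them only; others in the source may bear on it.

Two compounds of this series have numbers in an assay on CHO cells for displacement of a labelled ligand from adenosine receptor A3 (Homo sapiens), tested at 10 uM; on this read-out lower numbers stand for less inhibition and higher numbers for more inhibition at the one concentration tested (going by the name of the read-out). Compound 1 `OC[C@@]1(O)CO[C@@H](n2cnc3c(NCc4cccc(Cl)c4)ncnc32)[C@@H]1O` gives 43% in this assay. Compound 2 `CCNC(=O)OC[C@@H]1CO[C@@H](n2cnc3c(N)ncnc32)[C@@H]1O` gives 8% in this assay, the lowest of the two numbers, and it lies beyond the scatter under compound 1. The two differ in more than one place, so their gap is read only as what the two values show.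

Compound 3 `CCNC(=O)[C@@H]1CO[C@@H](n2cnc3c(N)ncnc32)[C@@H]1O` is unmeasured. It differs from compound 2 in one place: ethylcarbamoyl in place of ((ethylcarbamoyl)oxy)methyl on a saturated ring carbon. The ethylcarbamoyl sits directly on the saturated ring carbon where compound 2 carries ((ethylcarbamoyl)oxy)methyl. Among the compounds with values here, no measured pair makes this change, so its size in this assay is not fixed by any step seen here; a rise beyond the scatter is expected, since a low starting number leaves little room for a drop, but the range must stay wide. The expected step from compound 2 to compound 3 is a number 47 percentage points higher from compound 2 to compound 3 (beyond the scatter). For compound 3 the estimate in this assay is 55%, with a range from 20% to 90%.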

Compound 3, a percentage reported as inhibition, at one concentration (the size of the read-out at that concentration, not a potency): 10%
Compound 3: the middle estimate sits 45 percentage points above what was measured, and the stated range ends above it.
By their numbers in this assay, from the lowest: compounds 2 and 3 (each within the scatter of the next); then compound 1.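

In this assay, ethylcarbamoyl in place of ((ethylcarbamoyl)oxy)methyl on a saturated ring carbon gives a number 2 percentage points higher from compound 2 to compound 3 (within the scatter). Within the data shown here, this is the first step that changes one place only, and it shows that, at the one concentration tested, this read-out does not separate the two groups at this position, even though the entering group has fewer heavy atoms and one hydrogen-bond acceptor fewer than the group it replaces. No measurement on the compounds shown bears on why the two groups read alike.

As far as these compounds go, it remains open whether a different group on this ring carbon, such as a carboxylic acid, an amine or a longer chain on the amide nitrogen, would move the number in this assay beyond the scatter. From the compounds shown here alone, it also remains open whether the exchange of ethylcarbamoyl for ((ethylcarbamoyl)oxy)methyl would read the same on a core whose amino group carries a chlorobenzyl group, as the amino group of compound 1 does.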